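This account rests on a few compounds, and the source may have more. Where it says the series, first, only, none or still open, it means among the compounds named here.

Measured so far:
Compound 1 `Cc1ccc(/C=C/c2ncc([N+](=O)[O-])n2C)cc1`: > 100000 nM
Compound 2 `Cn1c([N+](=O)[O-])cnc1/C=C/c1cccc(Br)c1`: 87100 nM

Both compounds were tested in an ADME assay on HeLa cells (Homo sapiens) for cytotoxicity, read by resazurin assay, with a stated time of 2 days; a lower number here means a stronger inhibitor, a higher number a weaker inhibitor. In this assay compound 1 gives > 100000 nM, which is a limit of the assay and not a number. Compound 1 therefore has no exact position in the series, and its standing is the limit of > 100000 nM in this assay, at which 1 of the 2 values shown sits. Among the measured compounds shown here, in the same assay, compound 2 gives 87100 nM, the only true number so far.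

The next compound to be measured is compound 3 `Cn1c([N+](=O)[O-])cnc1/C=C/c1ccc(OC(F)(F)F)cc1`. It has trifluoromethoxy in place of methyl on an aromatic carbon, para to a large group (trifluoromethoxy in place of methyl on an aromatic carbon). For the measured compounds named here, no measured step covers this change, so the expectation rests on thin ground. Compound 2, with 87100 nM, shows that a different group on the shared core can give a number in this assay.

A small step towards lower values, not clearly beyond the scatter, is expected: an at least 1.2-fold lower number from compound 1 to compound 3 (0.09 log units; that floor lies within the scatter). Another limit instead of a number is also a real possibility. For compound 3 the estimated value is 80000 nM. The expected range for compound 3 runs from 35000 nM to 150000 nM.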

Compound 3, half-maximal inhibitory concentration: 83200 nM
The estimate for compound 3 lay 1.0-fold (0.02 log units) below the measured number; measured number inside the range.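

Trifluoromethoxy in place of methyl on an aromatic carbon, para to a large group, is the first change at this position that can be read in this assay, and compound 3 has a true number there. The pair gives an at least 1.2-fold lower number from compound 1 to compound 3 (0.07 log units; that floor lies within the scatter). This is a floor and not the size of the step, and compound 1 stands at a limit and not at a number: the limit of > 100000 nM in this assay, at which 1 of the 3 values shown sits.

The pair therefore fixes neither the true size of the step nor its direction beyond the scatter, and a single change cannot separate the contribution of the entering oxygen from that of the fluorines. An amine or a carboxylic acid at the same place on the shared core, or a longer chain such as ethoxy, would test whether true numbers in this assay extend to other groups at this position or remain limited to trifluoromethoxy.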